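Allyl in place of 4-methylphenyl: working notes

The source may hold more compounds than are shown below. What is called first, only, known or untested is meant among the compounds shown, and "the series" means these compounds.

In a functional assay on T47D cells (Homo sapiens) for cytotoxicity, read by MTT assay, with a stated time of 48 h (on this read-out lower numbers stand for stronger inhibition and higher numbers for weaker inhibition), compound 2 `Cc1ccc(NC(=S)N/N=C\c2ccnc3ccccc23)cc1` gives 1320 nM and compound 1 `COc1ccc(NC(=S)N/N=C\c2ccnc3ccccc23)cc1` gives 1360 nM, so the two stand level within the scatter. Among the compounds with values here, the only measured step is a 1.0-fold lower number from compound 1 to compound 2 (0.01 log units; within the scatter), with methyl in place of methoxy on an aromatic carbon. Compound 3 `C=CCNC(=S)N/N=C\c1ccnc2ccccc12` carries allyl in place of 4-methylphenyl on an amide-type nitrogen. The measured step bears on this only weakly, since it keeps the six-membered aromatic ring and compound 3 loses it. Within the data shown here, no measured pair shows what losing that ring does, so the size of the step is poorly constrained. A moderate move towards a higher number in this assay is tentatively expected. The expected step is a 2.3-fold higher number from compound 2 to compound 3 (0.36 log units; beyond the scatter). Compound 3 is estimated at 3000 nM, with an expected range of 1000 nM to 9000 nM.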

Compound 3, half-maximal inhibitory concentration: 1230 nM
Compound 3: middle estimate off by 2.4-fold (0.39 log units), on the high side; the measured number falls inside the stated range.
By their numbers in this assay, from the lowest: compounds 3, 2 and 1 (each within the scatter of the next).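

In this assay the step of a 1.1-fold lower number from compound 2 to compound 3 (0.03 log units; within the scatter) and the step of a 1.1-fold lower number from compound 1 to compound 3 (0.04 log units; within the scatter) show that the six-membered aromatic ring on the amide-type nitrogen can be replaced by allyl without a change beyond the scatter. Within the data shown here, the earlier pair only varied the substituent on that ring, so this is the first reading of what removing the ring does: with 3 heavy atoms in place of 7, the read-out stays level across all three compounds. No measurement available here explains why the read-out holds level across this change.

Whether this flat picture extends beyond these three groups remains open, as an amine-bearing chain, a carboxylic acid or a longer alkyl chain on the same nitrogen is not among the compounds shown. Also open, on these data alone, is whether any group at this position moves the number beyond the scatter at all.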